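A Single Stereocentre Flipped in a Weakly Cytotoxic Pair

The source may report more compounds than this note shows. Statements on the series, on what has been measured and on what is new or still open speak of the compounds shown alone.

In a functional assay on HL-60 cells (Homo sapiens) for cytotoxicity, read by WST assay, with a stated time of 48 h (a lower number here means a stronger inhibitor, a higher number a weaker inhibitor), compound 1 `COC[C@@H](C(C)C)C(c1ccc(O)c(OC)c1)c1ccc(O)c(OC)c1` gives 54000 nM, and compound 2 `COc1ccc(C(c2ccc(OC)c(OC)c2)[C@H](C)[C@@H](C)CO)cc1OC` gives 47000 nM. Compound 2 holds the lowest of the two numbers, but its gap to compound 1 lies within the scatter, so the pair cannot be ordered. Compound 3 `COc1ccc(C(c2ccc(OC)c(OC)c2)[C@H](C)[C@H](C)CO)cc1OC` is the next case: the two compounds have the same atoms and bonds and differ only in configuration as drawn: 1 of 2 stereo elements differ; a stereocentre at a saturated chain carbon is drawn R in compound 2 and S in compound 3. For the measured compounds named here, no measured pair shows how such a change plays out here. One therefore expects a step of a 1.1-fold higher number from compound 2 to compound 3 (0.03 log units; within the scatter) no larger than the scatter, in either direction. The estimated value for compound 3 is 50000 nM, within 20000 nM to 125000 nM.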

Compound 3, half-maximal inhibitory concentration: > 100000 nM
Compound 3 gave a limit, no number (the forecaster's own chance of this, stated with the estimate: 10%); at least 2.0-fold (0.30 log units) between middle value and limit.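

In this assay, the step is an at least 2.1-fold higher number from compound 2 to compound 3 (0.32 log units; beyond the scatter) and gives the first sign that the configuration at this saturated chain carbon counts in this series. Compound 3 gives > 100000 nM as a limit of the assay, not a number. The step can be traced to this one stereocentre alone because of a single fact: the fact that compounds 2 and 3 differ only in the configuration as drawn.

On these data alone, whether the other stereocentre is as sensitive remains open. As far as these compounds go, it is also open how an amine or a carboxylic acid in place of the chain's hydroxyl would respond to the same change in configuration.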